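A pyridin-3-yl swap on compound 2

The source may report more compounds than this note shows. Statements on the series, on what has been measured and on what is new or still open speak of the compounds shown alone.

Among the measured compounds shown here, in a functional assay on BT-549 cells (Homo sapiens) for inhibition, read by sulforhodamine B assay, with a stated time of 6 days (on this read-out lower numbers stand for stronger inhibition and higher numbers for weaker inhibition), compound 2 (`CNCCNCc1cccc(-c2nc(Nc3ccccc3)c(C)c(-c3c(C)nn(C)c3C)n2)c1`) gives 8200 nM as the only actual number among the three compounds measured so far. Compound 1 (`CNCCNCc1cccc(-c2nc(NC3CCOCC3)c(C)c(-c3cncnc3)n2)c1`) gives > 50000 nM as a limit of the assay. Compound 3 (`CNCCNCc1cccc(-c2nc(NC3CCOCC3)c(C)c(-c3c(C)nn(C)c3C)n2)c1`) gives > 50000 nM as a limit too.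

Compound 4 (`CNCCNCc1cccc(-c2nc(Nc3ccccc3)c(C)c(-c3cccnc3)n2)c1`) differs from compound 2 in one place: pyridin-3-yl in place of 1,3,5-trimethyl-1H-pyrazol-4-yl on an aromatic carbon and this place is an aromatic carbon ortho to a methyl group. For the measured compounds named here, only one measured step changes the group at this position, and a step that the two limits leave unreadable from compound 1 to compound 3 gives no usable size. The step of an at least 6.0-fold higher number from compound 2 to compound 3 (0.78 log units; beyond the scatter) concerns the group on the nitrogen instead, so it does not measure this swap.

With no readable step at this position, no shift beyond the scatter is expected in this assay. Compound 2 at 8200 nM remains the best anchor. The expected change is a 1.0-fold lower number from compound 2 to compound 4 (0.01 log units; within the scatter) as an estimate only. Compound 4 is estimated at 8000 nM with an expected range of 2500 nM to 26000 nM in this measurement.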

Compound 4, half-maximal inhibitory concentration: 14100 nM
The estimate for compound 4 lay 1.8-fold (0.25 log units) below the measured number, within the range that was stated.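

In this assay, the swap gives a 1.7-fold higher number from compound 2 to compound 4 (0.24 log units; within the scatter), so with the anilino group held constant, pyridin-3-yl and 1,3,5-trimethyl-1H-pyrazol-4-yl cannot be told apart at this position. The earlier step at this position, between compound 1 and compound 3, cannot be read, which makes this the first measured size for a change here. That size could only come from a pair with two actual numbers, because both compounds carrying the oxan-4-yl group give no number: the limit of > 50000 nM in this assay, at which 2 of the 4 values shown sit.

Going by these compounds, whether a group without an aromatic ring at this position, such as an amine or a short alkyl chain, would move the number beyond the scatter remains open. On these data alone, it is also open whether a plain phenyl ring here would behave like these two rings.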